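Swapping a hydroxyl for a ketone on the side chain

The source may report more compounds than this note shows. Statements on the series, on what has been measured and on what is new or still open speak of the compounds shown alone.

Measured so far:
- compound 1 `CCCCCC(=O)/C=C/[C@H]1[C@H](O)CC(=O)[C@@H]1C/C=C\CCCC(=O)OC`: 28000 nM
- compound 2 `CCCCC[C@H](O)/C=C/[C@]1(O)C[C@@H](O)C=C1C/C=C\CCCC(=O)OC`: 201000 nM

Of the compounds shown here, two have been tested in a functional assay on K562 cells (Homo sapiens) for antiproliferative activity; on this read-out lower numbers stand for stronger inhibition and higher numbers for weaker inhibition. Compound 1 gives 28000 nM, while compound 2 gives 201000 nM, the higher of the two numbers and therefore the weaker inhibitor; the gap between them lies beyond the usual scatter. The two differ in more than one place, so no single change can be read out of that gap.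

Compound 3 `CCCCCC(=O)/C=C/[C@]1(O)C[C@@H](O)C=C1C/C=C\CCCC(=O)OC` keeps the core of compound 2 and alters only the side chain: pentylcarbonyl in place of 1-hydroxyhexyl on a double-bonded chain carbon bound to a double-bonded chain carbon. The same pentylcarbonyl chain is carried by compound 1, the compound with the lower number in this assay, but compound 1 also has a different core, so the side-chain change cannot be isolated from what is already measured. On that basis a moderate downward step, somewhat beyond the scatter, is expected from compound 2 to compound 3, a 2.5-fold lower number from compound 2 to compound 3 (0.40 log units; beyond the scatter), with real uncertainty in both directions. Compound 3 is estimated at 80000 nM in this assay, within a range from 25000 nM to 250000 nM.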

Compound 3, half-maximal inhibitory concentration: 20000 nM
Beside the measured number, compound 3's estimate is 4.0-fold (0.60 log units) above it; the measured number lies below the stated range.
By their numbers in this assay, from the lowest: compounds 3 and 1 (each within the scatter of the next); then compound 2.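

With the core held the same in compound 2 and compound 3, the side chain can now be read on its own in this assay: pentylcarbonyl in place of 1-hydroxyhexyl gives a 10-fold lower number from compound 2 to compound 3 (1.00 log units; beyond the scatter), a change well outside ordinary measurement noise. At this place, on a double-bonded chain carbon bound to a double-bonded chain carbon, the swap keeps the number of heavy atoms but removes a hydrogen-bond donor and a defined stereocentre, and it brings in a carbonyl double bond, and this single step cannot show which of these differences matters. Nothing available here offers an explanation for the size of the step.

From the compounds shown here alone, it remains open whether the hydroxyl itself is the feature that weakens inhibition, something a methoxy group or the opposite hydroxyl configuration on the same chain could help to separate. Going by these compounds, it is also open how a shorter or longer chain, or an amine, would behave at this place, and whether the same swap would have a similar effect on the core of compound 1.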